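The source may report more compounds than this note shows. Statements on the series, on what has been measured and on what is new or still open speak of the compounds shown alone.

In an ADME assay (liver) for metabolic stability, with Liver microsome (Homo sapiens) as the target, read by LC-MS, using microsomes and NADPH, with a stated time of 5 min, at 37 degrees C (on this read-out lower numbers stand for slow clearance and higher numbers for fast clearance), compound 1 `CCn1c([C@@H](C)NS(=O)(=O)c2ccccc2)nc2ccc(C(F)(F)F)cc21` gives 14 mL.min-1.g-1 and compound 3 `CCn1c([C@@H](C)NS(=O)(=O)c2cn(C)nc2C)nc2ccc(C(F)(F)F)cc21` gives 28 mL.min-1.g-1 so the two cannot be told apart, with a 2.0-fold higher number from compound 1 to compound 3 (0.30 log units; within the scatter) between them. Compound 2 `CCn1c([C@@H](C)NS(=O)(=O)c2cccc(C#N)c2)nc2ccc(C(F)(F)F)cc21` reads > 100 mL.min-1.g-1 which is a limit of the assay and not a number. Compound 3 stands clearly lower than that limit, as an at least 3.5-fold lower number from compound 2 to compound 3 (0.55 log units; beyond the scatter) shows.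

Going by the values given here, the next structure is compound 4 `CCn1c([C@@H](C)NS(=O)(=O)c2cnn(C(C)C)c2C)nc2ccc(C(F)(F)F)cc21` and its single change is 1-isopropyl-5-methyl-1H-pyrazol-4-yl in place of 1,3-dimethyl-1H-pyrazol-4-yl on a sulfonyl sulfur on the sulfonyl sulfur. The five-membered aromatic ring stays, and the entering group carries more carbon. Among the compounds with values here, no measured step exchanges one such ring for another. The closest guide is the exchange of phenyl on the sulfonyl sulfur, a 2.0-fold higher number from compound 1 to compound 3 (0.30 log units; within the scatter) whereas adding cyano gave a much larger move, an at least 7.1-fold higher number from compound 1 to compound 2 (0.85 log units; beyond the scatter) on a ring of a different kind. In this assay the expected step is small, estimated as a 1.4-fold higher number from compound 3 to compound 4 (0.13 log units; within the scatter) and not expected to pass the scatter. For compound 4 the estimated value is 38 mL.min-1.g-1 with an expected range from 14 mL.min-1.g-1 to 100 mL.min-1.g-1 around it.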

Compound 4, intrinsic clearance in microsomes: > 100 mL.min-1.g-1
Compound 4: only a limit was reported; the forecaster's own chance of this, stated with the estimate: 15%; at least 2.6-fold (0.42 log units) between middle value and limit.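

Replacing 1,3-dimethyl-1H-pyrazol-4-yl with 1-isopropyl-5-methyl-1H-pyrazol-4-yl on the sulfonyl sulfur keeps the five-membered aromatic ring and adds only carbon, yet this assay records an at least 3.5-fold higher number from compound 3 to compound 4 (0.55 log units; beyond the scatter). Against phenyl, the same position shows an at least 7.1-fold higher number from compound 1 to compound 4 (0.85 log units; beyond the scatter), whereas the earlier pyrazole of compound 3 could not be told apart from compound 1, so having this kind of ring on the sulfur does not by itself settle the read-out; the groups on the ring matter as well. Compound 4 sits at a limit of the assay and not at a number, so these steps have no upper size, and the step between compound 2 and compound 4 cannot be read: the limit of > 100 mL.min-1.g-1 in this assay, at which 2 of the 4 values shown sit.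

The compounds shown do not separate the effect of the isopropyl group from the different arrangement of methyl groups on the ring. Going by these compounds, how a 1-ethyl-5-methyl-1H-pyrazol-4-yl group, or a pyrazole carrying a hydroxyethyl chain, would read remains open.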